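Swapping the urea for a benzyl group on the ring nitrogen

The source may hold more compounds than are shown below. What is called first, only, known or untested is meant among the compounds shown, and "the series" means these compounds.

Measured compounds:
- compound 1 `CNC(=O)c1cnc(NC(=O)NC2CCCCC2)n2nc(-c3ccco3)nc12`: 18700 nM
- compound 2 `O=C(Nc1ncc(C(=O)O)c2nc(-c3ccco3)nn12)NC1CCCCC1`: 59400 nM
- compound 3 `CCOC(=O)c1cnc(NC2CC2)n2nc(-c3ccco3)nc12`: 9.52 nM

In an assay on CHO cells for displacement of a labelled ligand from adenosine receptor A3 (Homo sapiens) (on this read-out higher numbers stand for weaker inhibition and lower numbers for stronger inhibition), compound 2 gives the highest number of the three, so it is the weakest inhibitor shown; compound 1 is the nearest at 18700 nM, and compound 3 is far away at 9.52 nM. The only single-site step shown is a 3.2-fold higher number from compound 1 to compound 2 (0.50 log units; beyond the scatter), which concerns the carbonyl carbon and not the ring nitrogen.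

Compound 4 `COc1ccc(CNc2ncc(C(=O)O)c3nc(-c4ccco4)nn23)cc1` has not been measured. It differs from compound 2 in 4-methoxybenzyl in place of cyclohexylcarbamoyl on a nitrogen on an aromatic ring. Among the compounds with values here, no measured step touches this nitrogen, so the size of the step cannot be read from the data. Compound 3 carries a different small group on that same nitrogen together with an ester in place of the acid and is potent, but two things differ at once, so only its value is known. Because compound 2 still holds the acid at 59400 nM, compound 4 is expected to improve only modestly, with an expected step of a 9.9-fold lower number from compound 2 to compound 4 (1.00 log units; beyond the scatter) and an estimated value of 6000 nM ranging from 600 nM to 60000 nM.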

Compound 4, inhibition constant: 5520 nM
Compound 4: middle estimate off by 1.1-fold (0.04 log units), on the high side, and the stated range covers the measured number.
By their numbers in this assay, from the lowest: compound 3; then compound 4; then compound 1; then compound 2.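

In this assay, the change on the ring nitrogen gives an 11-fold lower number from compound 2 to compound 4 (1.03 log units; beyond the scatter), so this nitrogen clearly influences the read-out even with the carboxylic acid kept in place. It also shows that a urea-type cyclohexylcarbamoyl group is not needed here, since 4-methoxybenzyl gives the stronger inhibition of the two, although the swap changes several things at once: a non-aromatic ring gives way to an aromatic one, and the hydrogen-bond donor count falls. No measured evidence shows which of these differences accounts for the step.

From the compounds shown here alone, how an unsubstituted benzyl group on this nitrogen would compare with 4-methoxybenzyl remains open. Going by these compounds, it is also open whether the same swap would give a step of similar size with an ethyl ester in place of the acid.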